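Fluoro on the benzyl ring: compound 3 from compound 1

The source may report more compounds than this note shows. Statements on the series, on what has been measured and on what is new or still open speak of the compounds shown alone.

Among the measured compounds shown here, compound 1 `Cc1nc2c(OCc3ccccc3)cccn2c1N` stands highest of the two numbers so far: in a functional assay on the whole organism with Canis familiaris (Canis lupus familiaris) as the target, at a dose of 2 mg/kg by the intravenous route (on this read-out lower numbers stand for a weaker effect and higher numbers for a stronger effect at the one dose given), compound 1 gives 97%. Compound 2 `Nc1cnc2c(OCc3ccccc3)cccn12` gives 81% in this assay, and the step of a number 16 percentage points lower from compound 1 to compound 2 (beyond the scatter) is the only one measured. Compound 3 `Cc1nc2c(OCc3ccccc3F)cccn2c1N` differs from compound 1 by fluoro in place of hydrogen on an aromatic carbon. For the measured compounds named here, no measured step bears on this change; the step from compound 1 to compound 2 concerns hydrogen in place of methyl, not the fluoro. The expected step of a number 5 percentage points lower from compound 1 to compound 3 (within the scatter) is therefore none beyond the scatter. Compound 3 is estimated at 92%, between 75% and 100%.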

Compound 3, a percentage reported as inhibition, in the whole organism at one dose (the size of the read-out at that dose, not a potency): 93%
Beside the measured number, compound 3's estimate is 1 percentage points below it; low and high end bracket the measured number.
By their numbers in this assay, from the lowest: compound 2; then compounds 3 and 1 (each within the scatter of the next).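

Fluoro in place of hydrogen on the six-membered aromatic ring of carbon only, ortho to a large group, gives a number 4 percentage points lower from compound 1 to compound 3 (within the scatter) in this assay. Among the compounds shown here, the earlier pair spoke only to the methyl, so this is the first reading on this ring, and the change leaves no difference beyond the scatter at the one dose given. No measurement at hand offers an explanation for this outcome.

On these data alone, what a chloro or methoxy group would do at this place stays open. So does the effect of fluoro on the core of compound 2.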